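Aryl swap at the ring nitrogen: compound 3 to compound 4

A few compounds are considered here, and "the series" means these few. Any claim that something is new, unique, unknown or untested is made for them only; others in the source may bear on it.

Of the compounds shown here, three have been read in a functional assay on CHO-K1 cells for agonist activity at Glucose-dependent insulinotropic receptor (Homo sapiens), read by a luciferase reporter, with a stated time of 5 h; on this read-out higher numbers stand for an effect only at larger amounts of compound and lower numbers for an effect already at smaller amounts. Compound 3 `CC(C)OC(=O)N1CCC(Oc2ncnc3c2CCN3c2ccc(S(C)(=O)=O)cn2)CC1` gives 126 nM in this assay, the highest of the three numbers, yet neither neighbour lies beyond the scatter: in this assay compound 1 `CC(C)OC(=O)N1CCC(Oc2ncnc3c2CCN3c2ccc(-c3nccs3)cc2F)CC1` gives 79.4 nM, and in this assay compound 2 `CC(C)OC(=O)N1CCC(Sc2ncnc3c2CCN3c2ccc(S(C)(=O)=O)cc2F)CC1` gives 79.4 nM. No pair among these three differs in only one place, so the numbers say no more than that three different aryl groups on a nitrogen on an aromatic ring in a ring of the shared core return values within the scatter of one another.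

Compound 4 `CC(C)OC(=O)N1CCC(Oc2ncnc3c2CCN3c2ccc(C#N)c(F)c2)CC1` introduces (4-cyano-3-fluorophenyl in place of 5-(methylsulfonyl)pyridin-2-yl on a nitrogen on an aromatic ring in a ring). Among the measured compounds shown here, no measured pair tracks this change. Because compound 1 gives 79.4 nM and compound 2 gives 79.4 nM beside compound 3 at 126 nM, a further aryl exchange is expected to move the number little, with no step beyond the scatter in either direction. The expected step, a 1.3-fold lower number from compound 3 to compound 4 (0.10 log units; within the scatter), is taken as none beyond the scatter. In this assay compound 4 is estimated at 100 nM, within 40 nM to 250 nM.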

Compound 4, half-maximal effective concentration: 398 nM
Estimate against measurement, compound 4: 4.0-fold (0.60 log units) below, and the stated range ends below it.
By their numbers in this assay, from the lowest: compounds 1, 2 and 3 (each within the scatter of the next); then compound 4.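

In this assay, exchanging 5-(methylsulfonyl)pyridin-2-yl for 4-cyano-3-fluorophenyl on a nitrogen on an aromatic ring in a ring gives a 3.2-fold higher number from compound 3 to compound 4 (0.50 log units; beyond the scatter). This is the only single-place change among the compounds shown, and it establishes that the position responds to the identity of the aryl group, a dependence the earlier values, all within the scatter of one another, could not reveal. No available measurement ties the step to any particular difference between the two groups.

The exchange alters the ring atoms and the substituents together, so the contributions of the nitrile, the fluorine and the methylsulfonyl group remain unseparated. Also open, on these data alone, is how an aryl group carrying an amine or a carboxylic acid would read at this position.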